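Acetyl on a free hydroxy: compound 1 to compound 3

The source may report more compounds than this note shows. Statements on the series, on what has been measured and on what is new or still open speak of the compounds shown alone.

For the measured compounds named here, in a functional assay on A549 cells (Homo sapiens) for cytotoxicity, read by luminescence and CellTiter-Glo, with a stated time of 72 h (on this read-out lower numbers stand for stronger inhibition and higher numbers for weaker inhibition), compound 1 `O=C1C=CC[C@@H]([C@H](O)[C@H](O[C@@H](c2ccccc2)[C@@H](O)[C@@H]2CC=CC(=O)O2)c2ccccc2)O1` gives 7800 nM, the only numeric value so far. Compound 2 `O=C1C=CC[C@@H]([C@H](O)[C@@H](O[C@H]([C@@H]2CC=CC(=O)O2)[C@@H](O)c2ccccc2)c2ccccc2)O1` reads > 10000 nM, which is a limit of the assay. Compound 3 `CC(=O)O[C@@H]([C@@H]1CC=CC(=O)O1)[C@H](O[C@@H](c1ccccc1)[C@@H](O)[C@@H]1CC=CC(=O)O1)c1ccccc1` differs from compound 1 by acetyl in place of hydrogen on an oxygen on a saturated carbon, hydroxy to acetoxy. Going by the values given here, no measured step covers this change, so in this assay no step beyond the scatter is expected, in either direction, and the estimated step is a 1.1-fold lower number from compound 1 to compound 3 (0.05 log units; within the scatter). For compound 3 the estimate is 7000 nM, with an expected range of 2500 nM to 15000 nM.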

Compound 3, half-maximal inhibitory concentration: 6400 nM
Compound 3: middle estimate off by 1.1-fold (0.04 log units), on the high side; the range from low to high includes it.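

In this assay replacing hydrogen with acetyl on the oxygen on a saturated carbon gives a 1.2-fold lower number from compound 1 to compound 3 (0.09 log units; within the scatter) so, at this level of activity, the free hydroxy at this place is not required. For the compounds shown here, an acetoxy group is tolerated here, and this is the first numeric comparison.

From the compounds shown here alone, whether an amine or a longer ester at this place would also stay within the scatter remains open, as does acetyl on the remaining hydroxy. Compound 2 offers no numeric comparison, as its reading is a limit of the assay: the limit of > 10000 nM in this assay, at which 1 of the 3 values shown sits.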